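Swapping the aryl group on the hydrazone of compound 1

The source may hold more compounds than are shown below. What is called first, only, known or untested is meant among the compounds shown, and "the series" means these compounds.

Compound 1 `CN(C)CCn1cnnc1-c1cc(Oc2ccc(NC(=O)N/N=C/c3ccc(Cl)cc3Cl)cc2F)ccn1` gives 750 nM in a functional assay on MKN-45 cells (Homo sapiens) for cytotoxicity, read by MTT assay, with a stated time of 72 h (a higher number here means a weaker inhibitor, a lower number a stronger inhibitor), the lowest of the three numbers measured. Compound 2 `COc1ccc(/C=N/NC(=O)Nc2ccc(Oc3ccnc(-c4nncn4CCN(C)C)c3)c(F)c2)c(OC)c1` gives 1680 nM, and compound 3 `COc1ccc(/C=N/NC(=O)Nc2ccc(Oc3ccnc(-c4nncn4CCN(C)C)c3)c(F)c2)c(OC)c1OC` gives 2020 nM. Compound 4 `CN(C)CCn1cnnc1-c1cc(Oc2ccc(NC(=O)N/N=C/c3ccc(O)cc3)cc2F)ccn1` differs from compound 1 by 4-hydroxyphenyl in place of 2,4-dichlorophenyl on a carbon with a double bond to nitrogen. Among the measured compounds shown here, the steps that bear on this are the two earlier aryl swaps at the same carbon: a 2.2-fold higher number from compound 1 to compound 2 (0.35 log units; beyond the scatter) and a 2.7-fold higher number from compound 1 to compound 3 (0.43 log units; beyond the scatter), both modest weakenings; the step of a 1.2-fold higher number from compound 2 to compound 3 (0.08 log units; within the scatter) adds little. Replacing the 2,4-dichlorophenyl has so far cost some potency each time, so a modest weakening is expected here too, with a 2.3-fold higher number from compound 1 to compound 4 (0.36 log units; beyond the scatter) as the estimated step. Compound 4 is therefore expected to give about 1700 nM in this assay, within a range of 800 nM to 3600 nM.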

Compound 4, half-maximal inhibitory concentration: 820 nM
For compound 4 the middle estimate is 2.1-fold (0.32 log units) above the measured one; the measured number falls inside the stated range.
By their numbers in this assay, from the lowest: compounds 1 and 4 (each within the scatter of the next); then compounds 2 and 3 (each within the scatter of the next).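

Putting 4-hydroxyphenyl in place of 2,4-dichlorophenyl gives a 1.1-fold higher number from compound 1 to compound 4 (0.04 log units; within the scatter), so the two chlorines are not needed at this carbon to keep the number in this assay. The same ring gives a 2.5-fold lower number from compound 3 to compound 4 (0.39 log units; beyond the scatter) and a 2.0-fold lower number from compound 2 to compound 4 (0.31 log units; beyond the scatter), so the earlier weakening belongs to the two methoxy-bearing rings and not to every replacement of the dichlorophenyl. No measurement here explains why the hydroxy and dichloro rings sit so close.

As far as these compounds go, whether the hydroxyl itself matters stays open. A plain phenyl, 4-aminophenyl or 4-carboxyphenyl group at this carbon would help to settle that.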